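Methoxyphenyl swap on the carbonyl carbon: compound 2 to compound 3

The compounds below may be only part of what the source reports. "The series", "measured", "known", "first", "only" and "open" are said of these compounds alone.

Values so far in a functional assay on MCF7 cells (Homo sapiens) for antiproliferative activity, with a stated time of 5 days; on this read-out lower numbers stand for stronger inhibition and higher numbers for weaker inhibition:
- compound 1 `CCCCc1ccc2[nH]c(-c3ccc(OC)cc3)c(/C=N/O)c2c1` gives 212 nM
- compound 2 `CCCCc1ccc2[nH]c(-c3ccc(OC)cc3)c(/C=N/NC(=O)c3cccc(OC)c3)c2c1` gives "not determined" (no result reported)

Going by the values given here, compound 2 has no single number in this assay, so it cannot be placed against compound 1, and the series offers no measured step to scale from. Compound 3 `CCCCc1ccc2[nH]c(-c3ccc(OC)cc3)c(/C=N/NC(=O)c3ccccc3OC)c2c1` is still unmeasured. The structural change reads (2-methoxyphenyl in place of 3-methoxyphenyl on a carbonyl carbon), which is 2-methoxyphenyl in place of 3-methoxyphenyl on a carbonyl carbon. No step beyond the usual scatter is expected from this swap, and no direction can be given. Among the compounds with values here, the only anchor is compound 1 at 212 nM, and the data hold no reading for any compound carrying the methoxyphenyl carbonyl group, so the range stays wide. For compound 3 the expected value is 300 nM, with an estimated range of 40 nM to 2500 nM on this read-out.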

Compound 3, half-maximal inhibitory concentration: 71 nM
For compound 3 the middle estimate is 4.2-fold (0.63 log units) above the measured one; the measured number falls inside the stated range.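

In this assay, ((2-methoxyphenyl)carbonyl)amino in place of hydroxy on the double-bonded nitrogen gives a 3.0-fold lower number from compound 1 to compound 3 (0.48 log units; beyond the scatter), a modest step beyond the usual scatter. Going by these compounds alone, this is the first reading for a compound carrying a methoxyphenyl carbonyl group, and it shows that this position tolerates the group with stronger inhibition on this read-out. No measured evidence bears on the reason for this step.

With no result for compound 2, the step to compound 3 cannot be read, so the swap of 3-methoxyphenyl for 2-methoxyphenyl on the carbonyl carbon remains unscaled. Also open is whether the gain depends on the methoxyphenyl group at all, as the compounds shown include no amine, carboxylic acid or longer chain on that carbonyl carbon.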